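Adding a Methyl to the Chain of Compound 3

This account rests on a few compounds, and the source may have more. Where it says the series, first, only, none or still open, it means among the compounds named here.

Compound 1 `O=C(CCc1ccccc1-c1ccccc1CSCCc1ccccc1)NS(=O)(=O)c1cccs1` gives 510 nM in an assay on isolated protein for binding affinity to prostaglandin E2 receptor EP3 subtype (Homo sapiens); on this read-out lower numbers stand for stronger inhibition and higher numbers for weaker inhibition.
Compound 2 `O=C(CCc1ccccc1-c1ccc(OCCCOc2cccc(CSCCc3ccccc3)c2)cc1)NS(=O)(=O)c1cccs1` gives 16 nM in this assay.
Compound 3 `Cc1cccc(OCCCOc2ccc(-c3ccccc3CCC(=O)NS(=O)(=O)c3cccs3)cc2)c1` gives 53 nM in this assay.

Of these three numbers, compound 3 stands second highest. Among the measured compounds shown here, its nearest neighbour is compound 2, reached through the one step measured here, a 3.3-fold higher number from compound 2 to compound 3 (0.52 log units; beyond the scatter), a change that sits on the far end of the molecule, away from the carbonyl. Compound 1, which lacks the long ether-linked side arm altogether, gives the number furthest from compound 3.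

Compound 4 `Cc1cccc(OCCCOc2ccc(-c3ccccc3CC(C)C(=O)NS(=O)(=O)c3cccs3)cc2)c1` differs from compound 3 in one place only: methyl in place of hydrogen on a saturated chain carbon bound to a carbonyl carbon and a saturated chain carbon. For the measured compounds named here, no measured step touches this part of the molecule. The step from compound 2 to compound 3 alters a distant group and says nothing about a branch beside the carbonyl, and compound 1 differs from compound 3 in other ways again. With no comparable change on record, the cautious expectation for compound 4 in this assay is a number close to that of compound 3, with no step beyond the usual scatter, a 1.0-fold higher number from compound 3 to compound 4 (0.02 log units; within the scatter). Compound 4 is therefore estimated at 55 nM, expected to fall between 15 nM and 200 nM.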

Compound 4, inhibition constant: 340 nM
Compound 4: middle estimate off by 6.2-fold (0.79 log units), on the low side; measured number outside the range, above it.
By their numbers in this assay, from the lowest: compound 2; then compound 3; then compounds 4 and 1 (each within the scatter of the next).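

Among the compounds shown here, this part of the chain responds to change, which the earlier compounds could not show, since none of them varies it. In this assay, the step is a 6.4-fold higher number from compound 3 to compound 4 (0.81 log units; beyond the scatter), beyond the usual scatter, and it comes from methyl in place of hydrogen on a saturated chain carbon bound to a carbonyl carbon and a saturated chain carbon. The added group is only one carbon atom, so even the smallest branch at this carbon is enough to move the number to a higher value, meaning weaker inhibition on this read-out, yet the data on hand offer no explanation for that rise.

With a single branch on record, the compounds shown leave open whether an ethyl group, a fluorine atom, a hydroxyl group or a second methyl on the same carbon would shift the number in the same direction, and by a similar amount. They also leave open whether a methyl on this carbon would have a comparable effect in compound 2, which carries the phenethylsulfanyl group that compound 3 lacks.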